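The compounds below may be only part of what the source reports. "The series", "measured", "known", "first", "only" and "open" are said of these compounds alone.

Three sulfonamides have been run in an assay on isolated protein for inhibition of malate dehydrogenase, mitochondrial (Sus scrofa), with stated times of 45 min and 30 min (a higher number here means a weaker inhibitor, a lower number a stronger inhibitor), so far. Compound 1 `O=S(=O)(Nc1ccc(-c2nc3ccccc3o2)cc1)c1ccc(Cl)c(C(F)(F)F)c1` gives > 63000 nM, which is a limit of the assay rather than a number. Compound 2 `O=S(=O)(Nc1ccc2oc(-c3ccccc3)nc2c1)c1cccc(F)c1` gives > 63000 nM, again only a limit. Compound 3 `COc1cccc(S(=O)(=O)Nc2ccc(-c3nc4ccccc4o3)cc2)c1` gives > 63000 nM, also a limit. Compound 2 therefore stands where every measured compound stands, at the limit of > 63000 nM in this assay, at which 3 of the 3 values shown sit, and nothing separates it from compound 1 or compound 3 on the numbers. For the measured compounds named here, no two measured compounds differ in one place, so no measured step is available for this assay.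

Compound 4 `CS(=O)(=O)Nc1ccc2oc(-c3ccccc3)nc2c1` is the next to be measured, and the change from compound 2 is methyl in place of 3-fluorophenyl on a sulfonyl sulfur. Going by the values given here, the step in this assay is expected to be none beyond the scatter, because the limit of > 63000 nM in this assay, at which 3 of the 3 values shown sit, is where all three measured values sit and no measured step indicates movement. The step expected from compound 2 to compound 4 is a step that the limit leaves unreadable from compound 2 to compound 4, and compound 4 is expected to return a limit again rather than a number. Compound 4 is estimated at 100000 nM in this assay, with a range from 30000 nM to 500000 nM.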

Compound 4, half-maximal inhibitory concentration: > 63000 nM
Compound 4 was reported as a limit; the forecaster's own chance of this, stated with the estimate: 85%; the middle value is on the limit's open side.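

In this assay compound 4 gives > 63000 nM, a limit and not a number. No step can be read between compound 2 and compound 4, since both rest on a limit: the limit of > 63000 nM in this assay, at which 4 of the 4 values shown sit.

The compounds shown leave open whether the group on the sulfonyl sulfur changes inhibition at all in this assay, as none of them gives a number.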